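A few compounds are considered here, and "the series" means these few. Any claim that something is new, unique, unknown or untested is made for them only; others in the source may bear on it.

Compound 1 `CC(=O)N1CCN(c2ccc(Nc3ncc(C(F)(F)F)c(N4Cc5cccc(N(C)S(C)(=O)=O)c5C4)n3)cc2)CC1`: 1300 nM
Compound 2 `COc1ccc(C(F)(F)F)cc1Nc1ncc(C(F)(F)F)c(N2Cc3cccc(N(C)S(C)(=O)=O)c3C2)n1`: > 30000 nM
Compound 3 `COc1cc(Nc2ncc(C(F)(F)F)c(N3Cc4cccc(N(C)S(C)(=O)=O)c4C3)n2)c(OC)cc1Cl`: 7300 nM

All three compounds were tested in a functional assay on A549 cells (Homo sapiens) for antiproliferative activity, read by spectrophotometry, with a stated time of 2 days; a lower number here means a stronger inhibitor of growth, a higher number a weaker inhibitor of growth. Compound 2 stands at > 30000 nM, which is a limit of the assay and not a number. Of the two true numbers, compound 3 holds the higher, at 7300 nM. Compound 1 gives 1300 nM, a gap beyond the scatter.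

The next compound, compound 4 `Cc1cc(C)cc(Nc2ncc(C(F)(F)F)c(N3Cc4cccc(N(C)S(C)(=O)=O)c4C3)n2)c1`, carries 3,5-dimethylphenyl in place of 4-chloro-2,5-dimethoxyphenyl on a nitrogen on an aromatic ring. Going by the values given here, one measured step bears on this change, since it swaps the group at the same place: an at least 4.1-fold lower number from compound 2 to compound 3 (0.61 log units; beyond the scatter). That step shows that the number in this assay can respond to this group, but it gives no direction for a group without oxygen or chlorine. No clear shift is therefore expected, and the anticipated change stays within the scatter, though with wide uncertainty. The expected change is a 1.2-fold higher number from compound 3 to compound 4 (0.09 log units; within the scatter). For compound 4 the estimated value is 9000 nM, with an expected range from 2500 nM to 30000 nM.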

Compound 4, concentration for 50% growth inhibition: > 30000 nM
Compound 4 gave a limit, no number; the forecaster's own chance of this, stated with the estimate: 20%; at least 3.3-fold (0.52 log units) between middle value and limit.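

In this assay, 3,5-dimethylphenyl in place of 4-chloro-2,5-dimethoxyphenyl on the nitrogen gives an at least 4.1-fold higher number from compound 3 to compound 4 (0.61 log units; beyond the scatter), a loss beyond the scatter. Compound 4 stands at > 30000 nM, which is a limit of the assay and not a number. Going by these compounds alone, the earlier step showed only that the number responds to the group at this place, whereas this one shows that a phenyl bearing only two methyl groups does not keep the level of compound 3, although compound 2, which carries methoxy and trifluoromethyl groups, goes against any simple reading that oxygen on this ring is enough.

From the compounds shown here alone, the step from compound 2 to compound 4 cannot be read, since both values are limits: the limit of > 30000 nM in this assay, at which 2 of the 4 values shown sit. Whether an amine or a carboxylic acid on this phenyl ring would bring the number down remains open.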